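Bromine in place of fluorine on the amide phenyl

The compounds below may be only part of what the source reports. "The series", "measured", "known", "first", "only" and "open" are said of these compounds alone.

Three measured compounds share one core and differ in the phenyl group on an amide-type nitrogen. In a functional assay on A549 cells (Homo sapiens) for inhibition, read by CCK-8 assay, with a stated time of 72 h, tested at 10 uM (a lower number here means less inhibition of growth, a higher number more inhibition of growth at the concentration tested), compound 1 `CN(C)C(=O)c1cc2cnc(Nc3ccc(NC(=O)C4(C(=O)Nc5cccc(F)c5)CC4)cc3)nc2n1C1CCCC1` reads 91.8% with a 3-fluorophenyl there, compound 2 `COc1ccc(NC(=O)C2(C(=O)Nc3ccc(Nc4ncc5cc(C(=O)N(C)C)n(C6CCCC6)c5n4)cc3)CC2)cc1` reads 78.5% with a 4-methoxyphenyl, and compound 3 `CN(C)C(=O)c1cc2cnc(Nc3ccc(NC(=O)C4(C(=O)Nc5ccccc5F)CC4)cc3)nc2n1C1CCCC1` reads 88.6% with a 2-fluorophenyl. The gap a number 3.2 percentage points lower from compound 1 to compound 3 (within the scatter) is too small to separate those two fluorine-bearing compounds, while a number 10.1 percentage points higher from compound 2 to compound 3 (beyond the scatter) is a real but modest difference. Compound 3 therefore stands level with compound 1 and clearly over compound 2.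

Compound 4 `CN(C)C(=O)c1cc2cnc(Nc3ccc(NC(=O)C4(C(=O)Nc5ccc(Br)cc5)CC4)cc3)nc2n1C1CCCC1` has not yet been measured. Its change from compound 3 is 4-bromophenyl in place of 2-fluorophenyl on an amide-type nitrogen and amounts to 4-bromophenyl in place of 2-fluorophenyl on an amide-type nitrogen. Two steps offer some guidance. Swapping one fluorophenyl for the other gave the small gap already described, so that swap says little. For the measured compounds named here, the step of a number 13.3 percentage points lower from compound 1 to compound 2 (beyond the scatter) brought in the 4-methoxyphenyl and is the only one from compound 1 that clears the scatter. Going by the values given here, no measured compound carries bromine, so this guide is weak. A small fall is what is expected, namely a number 5.6 percentage points lower from compound 3 to compound 4 (within the scatter) in this estimate. In this assay compound 4 is estimated at 83% with an expected range of 70% to 93% at the tested concentration.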

Compound 4, percent growth inhibition at one concentration: 90.3%
For compound 4 the middle estimate is 7.3 percentage points below the measured one, within the range that was stated.
By their numbers in this assay, from the lowest: compound 2; then compounds 3, 4 and 1 (each within the scatter of the next).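

The bromine result shows that this position on the amide-type nitrogen accepts a 4-bromophenyl as well as either fluorophenyl in this assay: the reading shows a number 1.7 percentage points higher from compound 3 to compound 4 (within the scatter) and a number 1.5 percentage points lower from compound 1 to compound 4 (within the scatter), so these three compounds cannot be separated. The closest comparison is bromo in place of methoxy on an aromatic carbon, which gives a number 11.8 percentage points higher from compound 2 to compound 4 (beyond the scatter); among these compounds, the lower reading of compound 2 therefore goes with methoxy and not simply with having a group at the 4-position of the phenyl. The data shown offer no measurement that explains the difference between the bromo and methoxy compounds.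

From the compounds shown here alone, whether the high reading would survive a more different group on this phenyl remains open, for example an amine or a carboxylic acid in place of the bromine. Going by these compounds, because each compound was read at a single concentration, it also remains unknown whether compound 1, compound 3 and compound 4 would stay level at lower concentrations, where a full dose-response curve could reveal differences.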